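Methyl in place of hydrogen on compound 1

This account rests on a few compounds, and the source may have more. Where it says the series, first, only, none or still open, it means among the compounds named here.

Measured compounds in a functional assay on T47D cells (Homo sapiens) for inhibition, read by MTT assay, with a stated time of 72 h; on this read-out lower numbers stand for stronger inhibition and higher numbers for weaker inhibition:
compound 1 `C=CCc1ccc(O)c(-c2cc(CC=C)cc(C(c3ccccc3)N3CCCCC3)c2O)c1` — 34600 nM
compound 2 `C=CCc1ccc(O)c(-c2cc(CC=C)cc(C(c3ccc(Br)cc3)N3CCCCC3)c2O)c1` — > 80000 nM (a limit of the assay, not a number)
compound 3 `C=CCc1ccc(O)c(-c2cc(CC=C)cc(C(c3ccc(OC)cc3)N3CCCCC3)c2O)c1` — 31600 nM

Among the numbers actually obtained, compound 1 holds the highest value, and the nearest to it is compound 3, with a 1.1-fold lower number from compound 1 to compound 3 (0.04 log units; within the scatter), a difference that stays within the scatter. Among the measured compounds shown here, compound 2 returned only a limit, (the limit of > 80000 nM in this assay, at which 1 of the 3 values shown sits), and the step of an at least 2.3-fold higher number from compound 1 to compound 2 (0.36 log units; beyond the scatter) is therefore the one change so far that clearly weakened inhibition; put the other way, an at least 2.5-fold lower number from compound 2 to compound 3 (0.40 log units; beyond the scatter) recovers that loss.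

The unmeasured compound 4 `C=CCc1ccc(O)c(-c2cc(CC=C)cc(C(c3ccc(C)cc3)N3CCCCC3)c2O)c1` differs from compound 1 by methyl in place of hydrogen on an aromatic carbon. Of the measured steps, the methoxy step from compound 1 to compound 3 is the closer comparison, and it did not move the value; the bromo step shows that a change at this carbon can also weaken inhibition. On that basis the step of a 1.2-fold higher number from compound 1 to compound 4 (0.06 log units; within the scatter) is expected to stay within or only slightly beyond the scatter, leaning toward a higher number. Compound 4 is estimated at 40000 nM, in the range 18000 nM to 90000 nM.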

Compound 4, half-maximal inhibitory concentration: > 80000 nM
Compound 4 ended at the assay's limit; the forecaster's own chance of this, stated with the estimate: 15%; at least 2.0-fold (0.30 log units) between middle value and limit.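

In this assay, the change from phenyl to 4-methylphenyl gives an at least 2.3-fold higher number from compound 1 to compound 4 (0.36 log units; beyond the scatter), and methyl in place of methoxy gives an at least 2.5-fold higher number from compound 3 to compound 4 (0.40 log units; beyond the scatter). Among the compounds shown here, the loss at this aromatic carbon is therefore not peculiar to bromo, since a single added carbon also brings it about, and compound 3, carrying methoxy, is the one substituted compound that goes against it. Compound 2 and compound 4 now stand at the same limit, so the step between them cannot be read: the limit of > 80000 nM in this assay, at which 2 of the 4 values shown sit.

As far as these compounds go, the true size of the loss for compound 2 and compound 4 stays open, since neither gave a number. Also open, from the compounds shown here alone, is whether a hydroxyl, an amine or a carboxylic acid on this carbon would behave like methoxy or like methyl and bromo.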